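The source may hold more compounds than are shown below. What is called first, only, known or untested is meant among the compounds shown, and "the series" means these compounds.

Compound 1, `N/C(=N\NC(=S)N1CCOCC1)c1ccccn1`, carries no methyl on its aromatic ring, and in a functional assay on MCF7 cells (Homo sapiens) for cytotoxicity, read by MTT assay, with a stated time of 72 h (a lower number here means a stronger inhibitor, a higher number a weaker inhibitor), compound 1 gives 4700 nM. Compound 2, `Cc1ccnc(/C(N)=N/NC(=S)N2CCOCC2)c1`, adds that methyl. In this assay compound 2 reaches only a limit of the measurement, > 100000 nM. The step of an at least 21-fold higher number from compound 1 to compound 2 (1.32 log units; beyond the scatter) is thus large, and its size is only a lower bound because of the limit of > 100000 nM in this assay, at which 1 of the 3 values shown sits. Compound 3, `Cc1ccnc(/C(N)=N/NC(=S)N2CCCCCC2)c1`, keeps the methyl but replaces the morpholine ring with a seven-membered ring, and in this assay compound 3 gives 6900 nM.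

Compound 4, `Cc1ccnc(/C(N)=N/NC(=S)N2CCCCC2)c1`, differs from compound 2 in one place: piperidin-1-yl in place of morpholin-4-yl on a thiocarbonyl carbon. Going by the values given here, no measured step covers this exact exchange. Among the compounds with values here, the only measured step, from compound 1 to compound 2, concerns the methyl, not the ring, and so says little here. The values of compound 2 and compound 3 together suggest that changing the ring can bring the number down from the limit; piperidine sits between the two in size and heteroatom count, so a middling outcome is expected. Compound 4 is therefore estimated at 15000 nM, within a range of 4000 nM to 100000 nM, meaning an expected step of an at least 6.6-fold lower number from compound 2 to compound 4 (0.82 log units; beyond the scatter).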

Compound 4, half-maximal inhibitory concentration: 18800 nM
For compound 4 the middle estimate is 1.3-fold (0.10 log units) below the measured one, and the stated range covers the measured number.
By their numbers in this assay, from the lowest: compounds 1 and 3 (each within the scatter of the next); then compound 4. At a limit, above all of these: compound 2.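

With the methyl kept on the aromatic ring, the group on the thiocarbonyl carbon also matters: in this assay, piperidin-1-yl in place of morpholin-4-yl gives an at least 5.3-fold lower number from compound 2 to compound 4 (0.72 log units; beyond the scatter). Both groups are six-membered rings with six heavy atoms, and the exchange swaps the ring oxygen for a carbon, yet that single swap turns a limit into a measured number. The true size of the step stays unknown because the value of compound 2 is a limit and not a number: the limit of > 100000 nM in this assay, at which 1 of the 4 values shown sits.

The compounds shown leave open how a piperazine ring or an open-chain dimethylamino group at this place would compare with these rings. The methyl step is shown only with morpholin-4-yl on the thiocarbonyl carbon, so its size with piperidin-1-yl also stays open.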